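This account rests on a few compounds, and the source may have more. Where it says the series, first, only, none or still open, it means among the compounds named here.

Working notes on the series, read in a physicochemical assay for solubility, read by turbidimetry, measured as kinetic solubility, at pH 6.8; on this read-out lower numbers stand for lower solubility and higher numbers for higher solubility. Compound 1 (`C#Cc1cccc(N2C(=O)CSC2c2cccc(C(=O)NCCCCc3ccccc3)c2)c1`) gives 10000 nM, and compound 2 (`O=C(NCCCCc1ccccc1)c1cccc(C2SCC(=O)N2c2cccc(F)c2)c1`) gives 10000 nM, so the two stand level at the digits shown. Within the data shown here, only one measured step bears on what follows: no change at the digits printed from compound 1 to compound 2 (within the scatter), with fluoro in place of ethynyl on an aromatic carbon.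

Compound 3 (`O=C(NCCCCc1ccccc1)c1cccc(C2SCC(=O)N2c2ccccc2F)c1`) is the next entry. (2-fluorophenyl in place of 3-fluorophenyl on an amide-type nitrogen in a ring). In words, 2-fluorophenyl takes the place of 3-fluorophenyl on an amide-type nitrogen in a ring, with the same atoms joined differently. Among the measured compounds shown here, no measured pair tests a change of this kind, and the series holds no measured compound with the 2-fluorophenyl group, so the basis is thin.

The expectation rests on compound 2 at 10000 nM and on the size of no change at the digits printed from compound 1 to compound 2 (within the scatter). No step beyond the scatter is expected in this assay, in either direction, and the estimated step is no change at the digits printed from compound 2 to compound 3 (within the scatter). For compound 3 the expected value is 10000 nM, with an estimated range of 5000 nM to 15000 nM.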

Compound 3, solubility: 20000 nM
Estimate against measurement, compound 3: 2.0-fold (0.30 log units) below, and the stated range ends below it.
By their numbers in this assay, from the lowest: compounds 1, 2 and 3 (each within the scatter of the next).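

In this assay the first test of the same atoms joined differently at this position, 2-fluorophenyl in place of 3-fluorophenyl on an amide-type nitrogen in a ring, gives a 2.0-fold higher number from compound 2 to compound 3 (0.30 log units; within the scatter) and so stays within the scatter. The wider swap, 2-fluorophenyl in place of 3-ethynylphenyl at the same nitrogen, gives a 2.0-fold higher number from compound 1 to compound 3 (0.30 log units; within the scatter) and also stays within the scatter, so this read-out does not separate the three aryl groups shown, whether the comparison changes the substituent or where the fluorine sits on the ring. No measurement in hand speaks to what lies behind these numbers.

The compounds shown leave open whether a substituent of a different kind on this aryl ring, such as an amine or a carboxylic acid, would produce a step beyond the scatter in this assay. They also leave open whether a change elsewhere in the series, such as a shorter chain on the amide or a morpholine in place of the phenyl at its end, would do so.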